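The source may report more compounds than this note shows. Statements on the series, on what has been measured and on what is new or still open speak of the compounds shown alone.

Working notes on the series. Compound 3 `O=c1cc(CNCc2cccc(F)c2)oc2ccc(O)c(O)c12` carries a 3-fluorophenyl on the saturated chain carbon bound to the amine nitrogen of the shared core. In an ADME assay on Huh-7 cells (Homo sapiens) for cytotoxicity (on this read-out lower numbers stand for higher toxicity in this test and higher numbers for lower toxicity in this test), compound 3 gives only a limit of the assay, > 100000 nM, and no number. Compound 1 `O=c1cc(CNCc2ccccc2Cl)oc2ccc(O)c(O)c12` likewise gives a limit in this assay, > 100000 nM. Compound 2 `O=c1cc(CNCc2ccccc2O)oc2ccc(O)c(O)c12` also gives a limit, > 100000 nM. All three values sit at the limit of > 100000 nM in this assay, at which 3 of the 3 values shown sit, so compound 3 stands where every measured member of the series stands, at the ceiling of this assay.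

The steps among the measured compounds read a step that the two limits leave unreadable from compound 1 to compound 2, a step that the two limits leave unreadable from compound 1 to compound 3 and a step that the two limits leave unreadable from compound 2 to compound 3. The two that swap the aryl group on the chain carbon bear most directly on the present change, yet neither has a readable size.

Compound 4 `O=c1cc(CNCc2cccc([N+](=O)[O-])c2)oc2ccc(O)c(O)c12` is not yet measured. It differs from compound 3 by nitro in place of fluoro on an aromatic carbon, the nitro sitting meta to a large group. With every reference value at the limit, no step beyond the scatter is expected; the step from compound 3 to compound 4 is estimated as a number no higher from compound 3 to compound 4 (the limit leaves the size open). Compound 4 is therefore expected at 100000 nM, within a range from 50000 nM to 200000 nM, most probably reported again as a limit.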

Compound 4, half-maximal cytotoxic concentration: > 100000 nM
Compound 4 gave a limit, no number; the forecaster's own chance of this, stated with the estimate: 85%; the middle value sits exactly at the limit.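

Compound 3 and compound 4 both give only a limit in this assay, so no step can be read for nitro in place of fluoro, and the series stays at one ceiling: the limit of > 100000 nM in this assay, at which 4 of the 4 values shown sit. The compounds shown leave open whether any change on the shared core yields a measurable half-maximal cytotoxic concentration in this assay.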